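The source may report more compounds than this note shows. Statements on the series, on what has been measured and on what is new or still open speak of the compounds shown alone.

Measured so far:
- Compound 1 `O=S(=O)(Nc1ccc(-c2nc3ccccc3o2)cc1)c1cccc(O)c1`: in an assay on isolated protein for inhibition of malate dehydrogenase, mitochondrial (Sus scrofa), with stated times of 45 min and 30 min (on this read-out higher numbers stand for weaker inhibition and lower numbers for stronger inhibition), compound 1 gives > 63000 nM, a limit of the assay.
- Compound 2 `CS(=O)(=O)Nc1ccc(-c2nc3ccccc3o2)cc1`: compound 2 gives > 63000 nM, again a limit.
- Compound 3 `CCc1ccc(S(=O)(=O)Nc2ccc(-c3nc4ccccc4o3)cc2)cc1`: compound 3 gives > 63000 nM, also a limit.

Compound 3 therefore stands only at the limit of this assay, and every value shown sits at the limit of > 63000 nM in this assay, at which 3 of the 3 values shown sit. Compound 4 `O=S(=O)(Nc1ccc(-c2nc3ccccc3o2)cc1)c1ccc(Cl)c(Cl)c1` carries the change (3,4-dichlorophenyl in place of 4-ethylphenyl on a sulfonyl sulfur). Among the measured compounds shown here, the steps that bear on the group on the sulfonyl sulfur, a step that the two limits leave unreadable from compound 1 to compound 2, a step that the two limits leave unreadable from compound 1 to compound 3 and a step that the two limits leave unreadable from compound 2 to compound 3, are all unreadable, so no size or direction can be taken from them. For compound 4 the expectation in this assay is accordingly that the value again reaches no number, with an estimated 100000 nM and a range from 30000 nM to 400000 nM, which means an expected step that the limit leaves unreadable from compound 3 to compound 4.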

Compound 4, half-maximal inhibitory concentration: > 63000 nM
Compound 4 ended at the assay's limit; the forecaster's own chance of this, stated with the estimate: 85%; the middle value does not contradict the limit.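

In this assay compound 4 gives > 63000 nM, which is a limit and not a number. The steps to compound 4 from compound 1, compound 2 and compound 3 cannot be read: the limit of > 63000 nM in this assay, at which 4 of the 4 values shown sit.

As far as these compounds go, whether any group on the sulfonyl sulfur gives a measurable inhibition remains open.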